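A few compounds are considered here, and "the series" means these few. Any claim that something is new, unique, unknown or untested is made for them only; others in the source may bear on it.

Measured compounds, values in a functional assay on HeLa cells (Homo sapiens) for inhibition, read by sulforhodamine B assay; a lower number here means a stronger inhibitor, a higher number a weaker inhibitor:
compound 1 `COc1ccccc1NC1=CC(=O)c2c(nc3n2[C@H]2OC[C@@H](O)[C@H]2OC3)C1=O` — 7460 nM
compound 2 `O=C1C=C(NC2CCCC2)C(=O)c2c1nc1n2[C@H]2OC[C@@H](O)[C@H]2OC1` — > 16000 nM, a limit and not a number
compound 3 `CCOc1ccc(NC2=CC(=O)c3nc4n(c3C2=O)[C@H]2OC[C@@H](O)[C@H]2OC4)cc1` — 3110 nM

Compound 1 gives the highest of the two numbers; compound 3 sits a step below it. Compound 2 returns only (the limit of > 16000 nM in this assay, at which 1 of the 3 values shown sits).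

Compound 4 `O=C1C(NCc2ccccc2)=CC(=O)c2c1nc1n2[C@H]2OC[C@@H](O)[C@H]2OC1` differs from compound 1 by benzyl in place of 2-methoxyphenyl on an amine nitrogen. Going by the values given here, the only measured step touching the amine nitrogen is an at least 5.1-fold lower number from compound 2 to compound 3 (0.71 log units; beyond the scatter), where cyclopentyl gave a limit and 4-ethoxyphenyl a number. Compound 4 carries benzyl there, a cyclopentyl-like case rather than an aryl one, so the expected step of a 2.0-fold higher number from compound 1 to compound 4 (0.30 log units; within the scatter) runs toward a higher number, possibly to a limit again. Compound 4 is estimated at 15000 nM, between 6000 nM and 40000 nM.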

Compound 4, half-maximal inhibitory concentration: 11000 nM
Compound 4: middle estimate off by 1.4-fold (0.13 log units), on the high side; measured number inside the range.
By their numbers in this assay, from the lowest: compound 3; then compounds 1 and 4 (each within the scatter of the next). At a limit, above all of these: compound 2.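

In this assay, benzyl in place of 2-methoxyphenyl on the amine nitrogen gives a 1.5-fold higher number from compound 1 to compound 4 (0.17 log units; within the scatter), so the two compounds cannot be told apart in this assay. The amine nitrogen therefore tolerates benzylamino as well as (2-methoxyphenyl)amino, and the ring need not be attached directly to the nitrogen for a number to be returned. Compound 2, with cyclopentyl, remains a limit and not a number: the limit of > 16000 nM in this assay, at which 1 of the 4 values shown sits.

Still open, on these data alone, is whether a longer chain such as phenethyl also returns a number at this nitrogen. It is equally unclear whether a methoxy group on the benzyl ring would shift the value of compound 4.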